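The source may report more compounds than this note shows. Statements on the series, on what has been measured and on what is new or still open speak of the compounds shown alone.

Compound 1 `N#Cc1ccc(NC(=O)c2ccc3cccnc3c2O)c(F)c1` gives 370 nM in a functional assay on NALM-6 cells (Homo sapiens) for cytotoxicity, read by luminescence and CellTiter-Glo, with a stated time of 3 days; on this read-out higher numbers stand for weaker inhibition and lower numbers for stronger inhibition. Compound 2 `O=C(Nc1ccc(C(F)(F)F)cc1)c1cc(Br)c(F)cc1O` gives 1300 nM. Compound 3 `N#Cc1ccc(NC(=O)c2ccc3cccnc3c2O)cc1` gives 130 nM.

Compound 1 and compound 3 share one core and differ in a single place: hydrogen in place of fluoro on an aromatic carbon. That change brought a 2.8-fold lower number from compound 1 to compound 3 (0.45 log units; beyond the scatter). Compound 2 stands on a different core, and the difference between the two cores is not broken down here. Compound 4 `O=C(Nc1ccc(C(F)(F)F)cc1)c1cc(Br)ccc1O` is made from compound 2 by the same kind of change: hydrogen in place of fluoro on an aromatic carbon. The surroundings are not the same, though. In compound 1 the fluoro sits ortho to a large group and meta to a cyano group, whereas in compound 2 it sits ortho to a bromo group, meta to a hydroxy group and para to a large group, on the other half of the molecule.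

For the measured compounds named here, because the only measured example, a 2.8-fold lower number from compound 1 to compound 3 (0.45 log units; beyond the scatter), was made in different surroundings, the step from compound 2 to compound 4 is expected to be smaller and less certain, about a 1.5-fold lower number from compound 2 to compound 4 (0.18 log units; within the scatter). Compound 4 is therefore estimated at 850 nM, with a likely range from 350 nM to 2200 nM.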

Compound 4, half-maximal inhibitory concentration: 1090 nM
Compound 4: the middle estimate sits 1.3-fold (0.11 log units) below what was measured; the measured number falls inside the stated range.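

On the core of compound 2, hydrogen in place of fluoro gave a 1.2-fold lower number from compound 2 to compound 4 (0.08 log units; within the scatter) in this assay, a step too small to count as a real difference. Set beside the step on the other core, this result is not clearly different from it, as the two steps lie no further apart than repeated measurements of such steps can: the same change on two cores in this assay, a 2.8-fold lower number (0.45 log units; beyond the scatter) from compound 1 to compound 3 and a 1.2-fold lower number (0.08 log units; within the scatter) from compound 2 to compound 4, 2.4-fold (0.38 log units) apart, within the scatter of two such steps. The data therefore give no sign that the change behaves differently on the two cores, but they do not prove that it carries over unchanged either: one step lies beyond the scatter, the other within it, and two pairs are too few for a rule.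

Still open, going by these compounds, is how other groups on that same aromatic carbon, such as a chloro group, a methyl group or an amine, would read on either core. Equally open, on these data alone, is what a methoxy group in place of the hydroxy group would do on either core.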